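A few compounds are considered here, and "the series" means these few. Any claim that something is new, unique, unknown or untested is made for them only; others in the source may bear on it.

Measured compounds:
- compound 1, `CCN(Cc1ccoc1)C(=O)COc1ccc(C)cc1`, in an assay on HEK293 cells for agonist activity at transient receptor potential cation channel subfamily M member 8 (Homo sapiens), read by fluorescence and calcium flux, with a stated time of 15 min (a lower number here means that less compound is needed, a higher number that more compound is needed for the effect), compound 1 gives 136 nM
- compound 2, `Cc1ccc(OCC(=O)N(Cc2cccs2)c2ncco2)cc1`, in this assay compound 2 gives 0.3 nM

Compound 2 stands at the lower of the two numbers, and the gap to compound 1 is well beyond the usual scatter of this assay . The two differ in several places at once, so no single change can be tied to that gap.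

Compound 3, `Cc1ccc(OCC(=O)N(Cc2cccs2)c2nccs2)cc1`, has not yet been measured in this assay . It differs from compound 2 in one place: 1,3-thiazol-2-yl in place of 1,3-oxazol-2-yl on an amide-type nitrogen. Going by the values given here, no measured pair isolates this swap, so its size cannot be read from the data; the change keeps the ring size, the count of heavy atoms and the acceptor count, so a step within the scatter, or at most a small one in either direction, is expected from compound 2 to compound 3 a 1.7-fold higher number from compound 2 to compound 3 (0.22 log units; within the scatter). On that basis compound 3 is estimated at 0.5 nM, with a range from 0.1 nM to 3 nM.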

Compound 3, half-maximal effective concentration: 2240 nM
Compound 3: middle estimate off by 4500-fold (3.65 log units), on the low side; measured number above the stated range.
By their numbers in this assay, from the lowest: compound 2; then compound 1; then compound 3.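

In this assay the group on the amide-type nitrogen proves far from interchangeable: 1,3-thiazol-2-yl in place of 1,3-oxazol-2-yl gives a 7500-fold higher number from compound 2 to compound 3 (3.87 log units; beyond the scatter) even though the heavy-atom, donor and acceptor counts stay the same and only oxygen gives way to sulfur. This one-place change spans the full range of the three compounds, with compound 1, which differs from both in several places, lying between them, so this position can carry a very large step in the series. No measurement offered here accounts for the size of the step.

As far as these compounds go, it remains open whether phenyl, pyridin-2-yl or 1,3-oxazol-4-yl at this nitrogen would stay near compound 2 or move toward compound 3. From the compounds shown here alone, whether the same swap produces a similar step with ethyl on the nitrogen, or with another group in place of the thiophene-bearing chain, also remains open.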